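This account rests on a few compounds, and the source may have more. Where it says the series, first, only, none or still open, it means among the compounds named here.

Compound 1 `NC(=O)c1c(NC(=O)c2ccccc2Cl)sc2c1CCN(Cc1ccccc1Cl)C2`: 4430 nM
Compound 2 `NC(=O)c1c(NC(=O)c2ccccc2F)sc2c1CCN(Cc1ccc(Cl)cc1Cl)C2`: 9610 nM
Compound 3 `NC(=O)c1c(NC(=O)c2cccc([N+](=O)[O-])c2)sc2c1CCN(Cc1c(Cl)cccc1Cl)C2`: 13500 nM

All three were measured in a functional assay on MKN-74 cells (Homo sapiens) for antiproliferative activity, with a stated time of 24 h; on this read-out higher numbers stand for weaker inhibition and lower numbers for stronger inhibition. Compound 1 has the lowest number of the three, and its gaps to compound 2 and to compound 3 both lie beyond the usual scatter, so among these three compound 1 is the strongest inhibitor. For the measured compounds named here, the other two compounds each differ from compound 1 in more than one place, so no single-change step between measured compounds is available.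

Compound 4 `COc1ccccc1NC(=S)N1CCc2c(sc(NC(=O)c3ccccc3Cl)c2C(N)=O)C1` differs from compound 1 as follows: a group of 11 heavy atoms (8 carbon, 1 nitrogen, 1 oxygen, 1 sulfur; one six-membered aromatic ring of carbon only) in place of a group of 8 heavy atoms (7 carbon, 1 chlorine; one six-membered aromatic ring of carbon only), on an amine nitrogen in a ring. The group that enters is larger than the 2-chlorobenzyl group that leaves and brings a hydrogen-bond donor and acceptors where the old group had none, all on an amine nitrogen in a ring of the shared core.

Going by the values given here, nothing among the measured compounds shows what such a change does in this assay. The expectation is therefore a modest step from compound 1 to compound 4, with no clear direction, and the estimate for compound 4 is 5000 nM with a range of 1500 nM to 16000 nM, which means an expected step of a 1.1-fold higher number from compound 1 to compound 4 (0.05 log units; within the scatter).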

Compound 4, half-maximal inhibitory concentration: 35200 nM
Estimate against measurement, compound 4: 7.0-fold (0.85 log units) below, and the stated range ends below it.
By their numbers in this assay, from the lowest: compound 1; then compounds 2 and 3 (each within the scatter of the next); then compound 4.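

In this assay, the amine nitrogen in the ring of the shared core is not indifferent to what it carries: exchanging the 2-chlorobenzyl group for the larger group with a hydrogen-bond donor and acceptors gives a 7.9-fold higher number from compound 1 to compound 4 (0.90 log units; beyond the scatter), towards weaker inhibition. For the compounds shown here, this is the first single-change step available, and it shows that this position alone can move the number beyond the scatter, which the earlier compounds, differing in more than one place, could not show. Nothing measured here explains the rise.

From the compounds shown here alone, a single step cannot separate the size of the entering group from its other features, so it remains open which part of that group matters. Also open, going by these compounds, is how the number would respond to a plain benzyl group, a methyl group or an acetyl group on the same nitrogen, with the rest of the structure kept.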